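Tert-butyl for 4-fluorophenyl among three limit values

A few compounds are considered here, and "the series" means these few. Any claim that something is new, unique, unknown or untested is made for them only; others in the source may bear on it.

Of the compounds shown here, three have been tested in an ADME assay on Vero cells (Chlorocebus sabaeus) for cytotoxicity, read by MTT assay, with a stated time of 72 h; a lower number here means a stronger inhibitor, a higher number a weaker inhibitor: compound 1 (`O=C(O)c1cn(C2CC2)c2nc(N3CCC(N4CCCCC4)CC3)c([N+](=O)[O-])cc2c1=O`), compound 2 (`O=C(O)c1cn(-c2ccc(F)cc2)c2nc(N3CCC(N4CCCCC4)CC3)c([N+](=O)[O-])cc2c1=O`) and compound 3 (`O=C(O)c1cn2c(n1)CN(c1nc3c(cc1[N+](=O)[O-])c(=O)c(C(=O)O)cn3-c1ccc(F)cc1)CC2`). In this assay compound 2 gives > 126000 nM, which is a limit and not a number. Compound 1 gives > 141000 nM, which is also a limit. Compound 3 gives > 126000 nM, again a limit. None of the three therefore has a measured number.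

Compound 4 (`CC(C)(C)n1cc(C(=O)O)c(=O)c2cc([N+](=O)[O-])c(N3CCC(N4CCCCC4)CC3)nc21`) has not yet been measured. It carries tert-butyl in place of 4-fluorophenyl on an aromatic nitrogen. Going by the values given here, two measured steps bear on this change. The closer one is a step that the two limits leave unreadable from compound 1 to compound 2, with 4-fluorophenyl in place of cyclopropyl on an aromatic nitrogen. The other is a step that the two limits leave unreadable from compound 2 to compound 3, made on an aromatic carbon. Neither offers a size to carry over, so no step beyond the scatter is expected, in either direction. The expected change is a number no higher from compound 2 to compound 4 (the limit leaves the size open). Among the compounds with values here, the only anchor is compound 2 with its limit > 126000 nM, and compound 4 is expected to be reported as a limit too. For compound 4 the estimate is 126000 nM, with an expected range from 60000 nM to 260000 nM.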

Compound 4, half-maximal inhibitory concentration: > 136000 nM
Compound 4 ended at the assay's limit (the forecaster's own chance of this, stated with the estimate: 85%); middle value at least 1.0-fold (0.03 log units) from the limit.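

In this assay compound 4 gives > 136000 nM, which is a limit. The steps from compound 2 to compound 4 and from compound 1 to compound 4 cannot be read, as each joins two limits. The compounds shown leave open whether cyclopropyl, 4-fluorophenyl and tert-butyl on the aromatic nitrogen differ at all in this assay.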